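The source may report more compounds than this note shows. Statements on the series, on what has been measured and on what is new or still open speak of the compounds shown alone.

Compound 1 `N#Cc1ccc(F)cc1Cn1c(N2CCC[C@@H](N)C2)nc2cc[nH]c2c1=O` gives 3.33 h in an ADME assay on microsomes from liver (Homo sapiens) for metabolic stability, read by LC-MS, tested at 1 mM; a higher number here means that the compound lasts longer, a lower number that the compound disappears faster. Compound 2 `N#Cc1ccc(F)cc1Cn1c(N2CCC[C@@H](N)C2)nc2c(-c3ccc(S(N)(=O)=O)cc3)c[nH]c2c1=O` gives > 3.33 h, which is a limit of the assay and not a number. Compound 3 `CS(=O)(=O)c1ccc(-c2c[nH]c3c(=O)n(Cc4cc(F)ccc4C#N)c(N4CCC[C@@H](N)C4)nc23)c(F)c1` carries 2-fluoro-4-(methylsulfonyl)phenyl in place of 4-sulfamoylphenyl on an aromatic carbon. Among the compounds with values here, the only measured step that bears on this is a number no lower from compound 1 to compound 2 (the limit leaves the size open), and its size stays unreadable. On that basis, no change beyond the scatter and no direction is expected in this assay. The expected step, a step that the limit leaves unreadable from compound 2 to compound 3, is an estimate only. Compound 3 is expected at 3.4 h, with an estimated range of 1.7 h to 6.5 h.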

Compound 3, half-life: > 3.33 h
Compound 3: a limit, no number; the forecaster's own chance of this, stated with the estimate: 60%; the middle value lies beyond the limit too.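

In this assay compound 3 gives > 3.33 h as a limit of the assay and not a number. With a number no lower from compound 1 to compound 3 (the limit leaves the size open) the place on the five-membered aromatic ring now holds a phenyl group with 0 hydrogen-bond donors, where 4-sulfamoylphenyl had 1. The steps cannot be read for size, and the values shown meet at one limit: the limit of > 3.33 h in this assay, at which 2 of the 3 values shown sit.

From the compounds shown here alone, how far compound 2 and compound 3 lie beyond that limit stays open. Also open, going by these compounds, is what an amine or a carboxylic acid at this place would give in this assay on the same core.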